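Trifluoromethyl on the pyridine-type ring of compound 2

The source may hold more compounds than are shown below. What is called first, only, known or untested is meant among the compounds shown, and "the series" means these compounds.

Measured so far:
compound 1 `CC(Nc1nc(N)nc2ccn(Cc3ccccn3)c12)c1ccccn1`: > 24000 nM (limit)
compound 2 `Cc1cc(CNc2nc(N)nc3ccn(Cc4ccccn4)c23)no1`: > 24000 nM (limit)

In an ADME assay on HEK293 cells (Homo sapiens) for cytotoxicity, read by ATP content, with a stated time of 6 h (on this read-out higher numbers stand for lower toxicity in this test and lower numbers for higher toxicity in this test), compound 2 stands at > 24000 nM, which is a limit. Compound 3 `Cc1cc(CNc2nc(N)nc3ccn(Cc4cc(C(F)(F)F)ccn4)c23)no1` differs from compound 2 by trifluoromethyl in place of hydrogen on an aromatic carbon, opposite the ring nitrogen. Going by the values given here, the only measured step, a step that the two limits leave unreadable from compound 1 to compound 2, lies at another place and gives no size. The series offers only (the limit of > 24000 nM in this assay, at which 2 of the 2 values shown sit). No step beyond the scatter is expected in this assay, the estimated step being a number no higher from compound 2 to compound 3 (the limit leaves the size open). The expected value for compound 3 is 24000 nM, with an estimated range from 9000 nM to 48000 nM.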

Compound 3, half-maximal cytotoxic concentration: > 24000 nM
Compound 3: only a limit was reported (the forecaster's own chance of this, stated with the estimate: 70%); the middle value lies on the limit itself.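

The step between compound 2 and compound 3 cannot be read in this assay, and all values remain limits: the limit of > 24000 nM in this assay, at which 3 of the 3 values shown sit.

The compounds shown leave open whether trifluoromethyl in place of hydrogen on an aromatic carbon changes cytotoxicity, and where the half-maximal cytotoxic concentration of any of these compounds lies.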